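The compounds below may be only part of what the source reports. "The series", "measured", "known", "first", "only" and "open" are said of these compounds alone.

Measured compounds:
Compound 1, `CCOc1ccc(-c2nn3cc(-c4cccc(N)c4)nc3s2)cc1`: in a functional assay on CCRF-CEM cells (Homo sapiens) for inhibition, read by cell counting, with a stated time of 3 days (on this read-out lower numbers stand for stronger inhibition and higher numbers for weaker inhibition), compound 1 gives > 250000 nM, which is a limit of the assay rather than a number.
Compound 2, `Nc1cccc(-c2cn3c(-c4ccc(Cl)cc4)csc3n2)c1`: in this assay compound 2 gives 21000 nM.
Compound 3, `COc1ccc(-c2nn3cc(-c4cccc(N)c4)nc3s2)cc1`: in this assay compound 3 gives >= 250000 nM, again a limit rather than a number.

Among the measured compounds shown here, compound 2 thus stands as the only number among the three results, the other two being limits (the limit of > 250000 nM in this assay, at which 1 of the 3 values shown sits, (the limit of >= 250000 nM in this assay, at which 1 of the 3 values shown sits)). Compound 4, `COc1ccc(-c2csc3nc(-c4cccc(N)c4)cn23)cc1`, is the one still to be measured in this assay. It differs from compound 2 by methoxy in place of chloro on an aromatic carbon. For the measured compounds named here, the only measured step, a step that the two limits leave unreadable from compound 1 to compound 3, runs between two limits and so has no readable size; it also concerns a different exchange, on the shared core of compounds 1 and 3, not the move from chloro to methoxy. Going by the values given here, no measured step bears on the change at hand. With nothing pointing either way, the expected step from compound 2 to compound 4 is a 1.4-fold higher number from compound 2 to compound 4 (0.15 log units; within the scatter), that is, none beyond the usual scatter. Compound 4 is accordingly estimated at 30000 nM, with a range from 8000 nM to 150000 nM.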

Compound 4, half-maximal inhibitory concentration: 6100 nM
Compound 4: the middle estimate sits 4.9-fold (0.69 log units) above what was measured; the measured number lies below the stated range.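

In this assay, putting methoxy in place of chloro on the six-membered aromatic ring of carbon only, para to a large group, gives a 3.4-fold lower number from compound 2 to compound 4 (0.54 log units; beyond the scatter), a modest step, but one that shows that the group at this position matters on this core. Among the compounds shown here, it is also the first step that can be read, as the one between compound 1 and compound 3 runs between two limits. Nothing shown here accounts for the direction or size of this step.

As far as these compounds go, with only chloro and methoxy compared at this position, it remains open how an amine, a carboxylic acid or a longer chain such as butoxy would read there. From the compounds shown here alone, it is also open whether the exchange of chloro for methoxy would give a similar step on the core of compound 3.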